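This account rests on a few compounds, and the source may have more. Where it says the series, first, only, none or still open, it means among the compounds named here.

Measured so far, all in (a functional assay on A2780 cells (Homo sapiens) for inhibition, read by sulforhodamine B assay, with a stated time of 72 h; a higher number here means a weaker inhibitor, a lower number a stronger inhibitor):
- compound 1 `Cc1ccccc1S(=O)(=O)c1ccc(CNC(=O)c2cc3cnccc3[nH]2)cc1` gives 13 nM
- compound 2 `O=C(NCc1ccc(S(=O)(=O)c2ccccc2)cc1)c1cc2ccncc2s1` gives 14 nM
- compound 3 `O=C(NCc1ccc(S(=O)(=O)N2CCCCC2)cc1)c1cc2cnccc2o1` gives 1500 nM

Compound 3, at 1500 nM in this series, has the highest number of the three, and its distance from each of the other two lies beyond the scatter. The next step leads to compound 4 `O=C(NCc1ccc(S(=O)(=O)N2CCCCC2)cc1)c1cnc2nccn2c1`, with one change: a group of 9 heavy atoms (6 carbon, 3 nitrogen; one five-membered aromatic ring with 2 hetero atoms, one six-membered aromatic ring with 2 hetero atoms) in place of a group of 9 heavy atoms (7 carbon, 1 nitrogen, 1 oxygen; one five-membered aromatic ring with 1 hetero atom, one six-membered aromatic ring with 1 hetero atom), on a carbonyl carbon in compound 3. Within the data shown here, no measured pair differs in one place only, so the size of this swap in this assay has not been observed directly. Compound 1 at 13 nM and compound 2 at 14 nM show that much lower numbers occur in the series, but each differs from compound 3 in more than one place. A moderate move towards a stronger inhibitor, beyond the scatter, is therefore expected, with real uncertainty. The expected move is a 5.0-fold lower number from compound 3 to compound 4 (0.70 log units; beyond the scatter) as a working estimate. Compound 4 is estimated at 300 nM with an expected range from 40 nM to 2000 nM as the likely span.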

Compound 4, half-maximal inhibitory concentration: 130 nM
Estimate against measurement, compound 4: 2.3-fold (0.36 log units) above; the range from low to high includes it.
By their numbers in this assay, from the lowest: compounds 1 and 2 (each within the scatter of the next); then compound 4; then compound 3.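

In this assay the series now has its first step that differs in one place only, on a carbonyl carbon whose other neighbour is the amide-type nitrogen: a 12-fold lower number from compound 3 to compound 4 (1.06 log units; beyond the scatter) is a large change. This place therefore responds strongly to the exchange of one group for another of 9 heavy atoms, where the entering group has 2 hetero atoms in each aromatic ring and 3 hydrogen-bond acceptors rather than 2. No measurement available here accounts for the size of this step.

Going by these compounds, it remains open whether the same exchange gives a step of similar size in compounds carrying a different group on the sulfonyl. On these data alone, it also remains open how this place would respond if the entering group carried an added amine or carboxylic acid.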